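Naphthylmethyl triazole sulfonamides: bromopyridine variant of compound 3

A few compounds are considered here, and "the series" means these few. Any claim that something is new, unique, unknown or untested is made for them only; others in the source may bear on it.

Measured so far in an assay on HEK293 cells for inhibition of solute carrier family 22 member 12 (Homo sapiens); on this read-out lower numbers stand for stronger inhibition and higher numbers for weaker inhibition:
compound 1 `O=C(O)CSc1nnc(Br)n1Cc1ccc(Br)c2ccccc12`: 94 nM
compound 2 `Oc1c(Br)cc(CSc2nnc(Br)n2Cc2ccc(Br)c3ccccc23)cc1Br`: 119000 nM
compound 3 `O=S(=O)(CSc1nnc(Br)n1Cc1ccc(Br)c2ccccc12)Nc1ccc(F)nc1`: 1550 nM

Within this assay compound 3 holds the second highest of the three numbers. Its nearest neighbour is compound 1, whose number is lower; compound 2 is the furthest off, with a much higher number. For the measured compounds named here, the only single-place step measured so far, a 1300-fold higher number from compound 1 to compound 2 (3.10 log units; beyond the scatter), replaces the carboxy group on the chain carbon bound to sulfur, and so concerns a part of the molecule that compound 3 and compound 4 share unchanged.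

Compound 4 `O=S(=O)(CSc1nnc(Br)n1Cc1ccc(Br)c2ccccc12)Nc1ccc(Br)nc1Br` differs from compound 3 in one place: 2,6-dibromopyridin-3-yl in place of 6-fluoropyridin-3-yl on a sulfonamide nitrogen. Going by the values given here, no measured pair in the set changes the sulfonamide substituent, so nothing here speaks for a shift in either direction at this position. The working expectation for this assay is therefore a step from compound 3 to compound 4 that stays within the scatter, a 1.0-fold lower number from compound 3 to compound 4 (0.01 log units; within the scatter), with a wide margin on both sides for the lack of any precedent. Compound 4 is expected at 1500 nM, between 400 nM and 6000 nM.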

Compound 4, half-maximal inhibitory concentration: 5410 nM
The estimate for compound 4 lay 3.6-fold (0.56 log units) below the measured number; measured number inside the range.
By their numbers in this assay, from the lowest: compound 1; then compound 3; then compound 4; then compound 2.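

Notes on the sulfonamide nitrogen: in this assay the substituent at this place is the first on the sulfonamide side of the series to be tested by a single-place change, and the result is a 3.5-fold higher number from compound 3 to compound 4 (0.54 log units; beyond the scatter), a modest step beyond the scatter toward weaker inhibition. The position therefore responds to the pyridine substituent, and 2,6-dibromopyridin-3-yl is tolerated less well than 6-fluoropyridin-3-yl, although the shift is far smaller than a 1300-fold higher number from compound 1 to compound 2 (3.10 log units; beyond the scatter), the step at the chain carbon bound to sulfur. No measurement on hand accounts for the shift at the sulfonamide nitrogen.

The step combines the loss of the fluorine with the entry of two bromine atoms, so the compounds shown cannot assign the shift to either bromine or to the absence of fluorine. Also open, going by these compounds, is how the same place would respond to a plain pyridin-3-yl, a phenyl ring or a methyl group on the sulfonamide nitrogen, and whether any such group would bring the number in this assay lower than that of compound 3.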